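Step from compound 2 to compound 4 at a GnRH receptor

The source may report more compounds than this note shows. Statements on the series, on what has been measured and on what is new or still open speak of the compounds shown alone.

Measured so far:
- compound 1, `Cn1cnc(CN2CCN(c3cccc4[nH]c(-c5ccc(C(C)(C)C)cc5)nc34)CC2)c1`: 98 nM
- compound 2, `Cc1nc(CN2CCN(c3cccc4[nH]c(-c5ccc(C(C)(C)C)cc5)nc34)CC2)c[nH]1`: 28 nM
- compound 3, `CCc1nc(CN2CCN(c3cccc4[nH]c(-c5ccc(C(C)(C)C)cc5)nc34)CC2)cn1C`: 78 nM

All three compounds share one core and differ only in the five-membered ring hung on a saturated chain carbon bound to an amine nitrogen in a ring. In an assay on isolated protein for displacement of a labelled ligand from Gonadotropin-releasing hormone receptor (Rattus norvegicus) (a lower number here means a stronger inhibitor, a higher number a weaker inhibitor), compound 2 gives the lowest number of the three; its nearest neighbour is compound 3 with a 2.8-fold higher number from compound 2 to compound 3 (0.44 log units; beyond the scatter), and compound 1 lies further off with a 3.5-fold lower number from compound 1 to compound 2 (0.54 log units; beyond the scatter).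

Compound 4, `CCCn1c(CC)nc(C)c1CN1CCN(c2cccc3[nH]c(-c4ccc(C(C)(C)C)cc4)nc23)CC1`, has not yet been measured. Its change from compound 2 is 2-ethyl-4-methyl-1-propyl-1H-imidazol-5-yl in place of 2-methyl-1H-imidazol-4-yl on a saturated chain carbon bound to an amine nitrogen in a ring. The ring that enters carries a propyl on its ring nitrogen, so the hydrogen-bond donor of compound 2 is gone, and it is joined to the chain at a different ring position.

The step from compound 2 to compound 3, where the ring nitrogen likewise lost its hydrogen and gained a methyl, was a 2.8-fold higher number from compound 2 to compound 3 (0.44 log units; beyond the scatter), a modest loss. The step from compound 1 to compound 3, adding an ethyl on an aromatic carbon, stayed within the scatter. By analogy compound 4 is expected to lose ground against compound 2 by roughly a 3.6-fold higher number from compound 2 to compound 4 (0.55 log units; beyond the scatter), so compound 4 is estimated at 100 nM in this assay, with a plausible range from 35 nM to 300 nM.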

Compound 4, half-maximal inhibitory concentration: 120 nM
Beside the measured number, compound 4's estimate is 1.2-fold (0.08 log units) below it; measured number inside the range.
By their numbers in this assay, from the lowest: compound 2; then compounds 3, 1 and 4 (each within the scatter of the next).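

Replacing the small ring of compound 2 with the much larger 2-ethyl-4-methyl-1-propyl-1H-imidazol-5-yl gives a 4.3-fold higher number from compound 2 to compound 4 (0.63 log units; beyond the scatter) in this assay, which leaves compound 2, the only one of the four with a hydrogen on a ring nitrogen, as the strongest inhibitor. The larger ring cannot be told apart from the two other rings that lack this hydrogen: the comparison with the 2-ethyl-1-methyl-1H-imidazol-4-yl ring gives a 1.5-fold higher number from compound 3 to compound 4 (0.19 log units; within the scatter) and the comparison with the 1-methyl-1H-imidazol-4-yl ring gives a 1.2-fold higher number from compound 1 to compound 4 (0.09 log units; within the scatter), so this position takes 11 heavy atoms and a different point of attachment with no further loss that rises above the scatter. Nothing measured here explains why the numbers fall this way.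

Compound 4 differs from compound 2 in several features at once, so the propyl, the ethyl, the extra methyl and the new attachment point cannot be weighed separately. Going by these compounds, it also remains open whether a 2-ethyl-1H-imidazol-4-yl ring, which keeps the ring hydrogen, would match compound 2, and how a butyl on the ring nitrogen or a carboxylic acid on the ring would behave.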